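From 4-hydroxybut-1-yn-1-yl to pent-1-yn-1-yl at compound 4

A few compounds are considered here, and "the series" means these few. Any claim that something is new, unique, unknown or untested is made for them only; others in the source may bear on it.

In a functional assay on L1210 cells (Mus musculus) for inhibition (a higher number here means a weaker inhibitor, a lower number a stronger inhibitor), compound 1 `C#Cc1c(C#N)ncn1C1O[C@H](CO)[C@@H](O)[C@H]1O` gives 1.9 ug/mL, compound 2 `N#Cc1ncn(C2O[C@H](CO)[C@@H](O)[C@H]2O)c1C#CCO` gives 4.1 ug/mL, and compound 3 `N#Cc1ncn(C2O[C@H](CO)[C@@H](O)[C@H]2O)c1C#CCCO` gives 3.3 ug/mL. Compound 3 thus lies within the scatter of both other compounds: a 1.7-fold higher number from compound 1 to compound 3 (0.24 log units; within the scatter) and a 1.2-fold lower number from compound 2 to compound 3 (0.09 log units; within the scatter). Only a 2.2-fold higher number from compound 1 to compound 2 (0.33 log units; beyond the scatter) exceeds the scatter, and modestly.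

Compound 4 `CCCC#Cc1c(C#N)ncn1C1O[C@H](CO)[C@@H](O)[C@H]1O` replaces the 4-hydroxybut-1-yn-1-yl of compound 3 with pent-1-yn-1-yl, which places methyl in place of hydroxy on a saturated chain carbon, two bonds along the chain from a triple-bonded carbon. Going by the values given here, no measured pair makes this exact change, so the evidence is indirect. The chain steps from compound 1 and compound 2 are small, and the largest is a 2.2-fold higher number from compound 1 to compound 2 (0.33 log units; beyond the scatter). No step beyond the scatter is therefore expected, and the estimated change is a 1.1-fold higher number from compound 3 to compound 4 (0.03 log units; within the scatter). For compound 4 the expected value is 3.5 ug/mL, with an estimated range of 1.5 ug/mL to 8 ug/mL.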

Compound 4, half-maximal inhibitory concentration: 14.8 ug/mL
Compound 4: the middle estimate sits 4.2-fold (0.63 log units) below what was measured; the whole stated range lies below it.
By their numbers in this assay, from the lowest: compounds 1, 3 and 2 (each within the scatter of the next, the first and the last beyond it); then compound 4.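

In this assay, the exchange of hydroxy for methyl on a saturated chain carbon, two bonds along the chain from a triple-bonded carbon, gives the first clear separation in this series (a 4.5-fold higher number from compound 3 to compound 4 (0.65 log units; beyond the scatter)). Compound 4 also stands apart from the shorter hydroxymethyl-bearing alkyne (a 3.6-fold higher number from compound 2 to compound 4 (0.56 log units; beyond the scatter)) and from the parent with hydrogen on the triple-bonded carbon (a 7.8-fold higher number from compound 1 to compound 4 (0.89 log units; beyond the scatter)), whereas compound 3 lies within the scatter of both. Compound 3 and compound 4 differ only in hydroxy against methyl, so chain length alone does not account for the step. No supporting data bear on the origin of this result.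

As far as these compounds go, whether the hydroxy itself is the requirement remains open. An amine or a carboxylic acid in its place, or a longer chain carrying hydroxy, would test how specific the exchange is.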